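Heteroaryl swap at the core of compound 1

A few compounds are considered here, and "the series" means these few. Any claim that something is new, unique, unknown or untested is made for them only; others in the source may bear on it.

Measured so far:
compound 1 `Cc1cc(-c2c(CCc3ccccc3)c3cc(OCC(=O)NC(C)(C)c4ccccc4)ccc3[nH]c2=O)on1` — 45%
compound 2 `COCCCNC(=O)COc1ccc2c(c1)c(CCc1ccccc1)c(-c1ccc(F)cc1F)c(=O)n2C` — 0%
compound 3 `CC[C@H](NC(=O)COc1ccc2[nH]c(=O)c(-c3nccs3)c(CCc3ccccc3)c2c1)c1ccccc1` — 22%

In an ADME assay on microsomes from liver (Homo sapiens) for metabolic stability, with a stated time of 0.5 h (on this read-out lower numbers stand for a less stable compound and higher numbers for a more stable compound), compound 1 stands highest of the three numbers. The nearest is compound 3 with 22%, a gap beyond the scatter; the furthest is compound 2 with 0%, also beyond the scatter. No pair among these three differs in only one place, so no single step can be read from them.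

Compound 4 `CC(C)(NC(=O)COc1ccc2[nH]c(=O)c(-c3cccnc3)c(CCc3ccccc3)c2c1)c1ccccc1` has not been measured. It differs from compound 1 in one place: pyridin-3-yl in place of 3-methyl-1,2-oxazol-5-yl on an aromatic carbon. The amide side chain and the phenethyl group are shared with compound 1.

Within the data shown here, no comparable step exists among the measured compounds. With only the heteroaryl exchanged, the step of a number 5 percentage points lower from compound 1 to compound 4 (within the scatter) is expected to be small, probably within the scatter or a modest decrease. Compound 4 is therefore estimated at 40% in this assay, with a range from 20% to 60%.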

Compound 4, percent of the compound remaining: 83%
The estimate for compound 4 lay 43 percentage points below the measured number; the whole stated range lies below it.
By their numbers in this assay, from the lowest: compound 2; then compound 3; then compound 1; then compound 4.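

In this assay, pyridin-3-yl in place of 3-methyl-1,2-oxazol-5-yl gives a number 38 percentage points higher from compound 1 to compound 4 (beyond the scatter) while the amide side chain and the phenethyl group stay the same. This is the only single-place step among the compounds shown, and it makes this aromatic carbon, ortho to the phenethyl group, a site where one ring exchange alone moves the read-out by a large margin. Nothing shown explains the size or direction of the step.

Among these compounds, the single step cannot separate the contribution of the ring nitrogen's location from that of leaving the methyl-bearing five-membered ring, and a plain phenyl or a pyridin-4-yl group at the same carbon would bear on this. It also leaves open whether the gain carries over to other amide side chains.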